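The source may hold more compounds than are shown below. What is called first, only, known or untested is meant among the compounds shown, and "the series" means these compounds.

Measured so far:
- compound 1 `Cc1cccc2c1CCN2CCNC(=O)Nc1ccccc1Br`: in a functional assay for antagonist activity at transient receptor potential cation channel subfamily V member 1 (Rattus norvegicus), read by FLIPR (a lower number here means a less potent compound, a higher number a more potent compound, by a factor of ten per unit of this negative logarithm), compound 1 gives 7.4
- compound 2 `O=C(Nc1ccccc1Br)N[C@@H]1CCN(c2ccccn2)C1`: in this assay compound 2 gives only a limit, < 6.6

Among the compounds with values here, compound 1 stands as the only compound with a true number here; the other entry, for compound 2, is a limit of the assay rather than a number (the limit of < 6.6 in this assay, at which 1 of the 2 values shown sits), so no measured step between two compounds exists to set the scale.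

Compound 3 `O=C(NCCN1CCc2ccccc21)Nc1ccccc1Br` keeps the whole shared core of compound 1 and differs in one place: hydrogen in place of methyl on an aromatic carbon. Within the data shown here, with no measured step of this kind to lean on, the expectation is a small loss, of a size that may not rise beyond the scatter. For compound 3 the estimate in this assay is 7.1, within a range from 6.6 to 7.6, which corresponds to an expected step of a number 0.30 log units lower from compound 1 to compound 3 (within the scatter).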

Compound 3, negative logarithm of the antagonist equilibrium constant: 6.8
Beside the measured number, compound 3's estimate is 0.30 log units above it; measured number inside the range.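

Within the data shown here, the first measured step in this set, a number 0.60 log units lower from compound 1 to compound 3 (beyond the scatter), shows in this assay that this aromatic carbon is not indifferent to what it carries. Exchanging methyl, a single carbon, for hydrogen is enough to move the read-out beyond the usual scatter, and the methyl compound is the more potent of this pair. Nothing shown here explains why the methyl makes this difference.

As far as these compounds go, whether ethyl, chlorine or methoxy on the same aromatic carbon would raise the number further or lower it remains open. A single step also cannot tell whether the methyl would count for as much if the bromine on the other aromatic ring were replaced by another group.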